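Removing the Methyl from a Compound Already at the Limit

This account rests on a few compounds, and the source may have more. Where it says the series, first, only, none or still open, it means among the compounds named here.

Compound 2 `COc1cc(-c2nn(-c3cccc(NC(=O)Nc4cc(C(F)(F)F)cc(C(F)(F)F)c4)c3)cc2-c2ccncc2)ccc1Cl` stands at the top of the three values shown. In a functional assay on RPMI-8226 cells (Homo sapiens) for inhibition, read by sulforhodamine B assay, with a stated time of 48 h (a higher number here means a weaker inhibitor of growth, a lower number a stronger inhibitor of growth), compound 2 gives only a limit, > 50000 nM, and not a number. Compound 1 `O=C(Nc1cccc(-n2cc(-c3ccncc3)c(-c3ccc(Cl)c(O)c3)n2)c1)Nc1cccc(C(F)(F)F)c1` likewise reaches only a limit in this assay, > 32500 nM. Among the measured compounds shown here, compound 3 `COc1cc(-c2nn(-c3cccc(NC(=O)Nc4cccc(C(F)(F)F)c4)c3)cc2-c2ccncc2)ccc1Cl` is the one compound with a measured number in this assay, 3120 nM.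

The change from compound 2 to compound 4 `O=C(Nc1cccc(-n2cc(-c3ccncc3)c(-c3ccc(Cl)c(O)c3)n2)c1)Nc1cc(C(F)(F)F)cc(C(F)(F)F)c1` is hydrogen in place of methyl on an oxygen on an aromatic ring; cut one bond further out it reads methoxy to hydroxy, or 4-chloro-3-methoxyphenyl to 4-chloro-3-hydroxyphenyl. For the measured compounds named here, two measured steps bear on it. The step of an at least 10-fold lower number from compound 1 to compound 3 (1.01 log units; beyond the scatter) is the reverse of the present change on the same oxygen, and the step of an at least 16-fold lower number from compound 2 to compound 3 (1.20 log units; beyond the scatter) shows that the trifluoromethyl pattern of compound 2, which compound 4 keeps, already carries a large penalty. Both steps rest on limits, the limit of > 32500 nM in this assay, at which 1 of the 3 values shown sits, and (the limit of > 50000 nM in this assay, at which 1 of the 3 values shown sits), so their true sizes may be larger than stated. Removing the methyl is therefore expected to push the number further upward or leave it beyond reach of the assay. That amounts to an expected step that the limit leaves unreadable from compound 2 to compound 4. Compound 4 is therefore expected to give 150000 nM in this assay, within 50000 nM to 500000 nM, most likely reported only as a limit.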

Compound 4, concentration for total growth inhibition: > 50000 nM
Compound 4: no number, only a limit; the forecaster's own chance of this, stated with the estimate: 95%; the middle value does not contradict the limit.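

In this assay compound 4 gives > 50000 nM, a limit and not a number. Compound 1 and compound 2 also stand only at limits, so neither step to compound 4 can be read. The compounds shown leave open whether methoxy to hydroxy changes growth inhibition at all when the second trifluoromethyl is present.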